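The compounds below may be only part of what the source reports. "The series", "measured", "known", "first", "only" and "open" are said of these compounds alone.

Compound 2, `c1ccc2c(-c3cn4ccnc4c(-c4ccc5ncn(C6CCCCC6)c5c4)n3)cccc2c1`, gives 38.9% in a functional assay on HL-60 cells (Homo sapiens) for inhibition, read by sulforhodamine B assay, with a stated time of 48 h, tested at 10 uM (a higher number here means more inhibition at the concentration tested (going by the name of the read-out), a lower number less inhibition), the higher of the two numbers measured, while compound 1, `Brc1cn2ccnc2c(-c2ccc3ncn(C4CCCCC4)c3c2)n1`, gives 18% in this assay. Going by the values given here, the one measured step, a number 20.9 percentage points higher from compound 1 to compound 2 (beyond the scatter), shows that replacing bromo with naphthalen-1-yl raised inhibition beyond the scatter, though only modestly. Compound 3, `c1cn2cc(-c3ccsc3)nc(-c3ccc4ncn(C5CCCCC5)c4c3)c2n1`, differs from compound 2 by thiophen-3-yl in place of naphthalen-1-yl on an aromatic carbon. Among the compounds with values here, no measured step covers an exchange of one aromatic group for another on this carbon; the only guide is that compound 2 with naphthalen-1-yl sits above compound 1 with bromo. Thiophen-3-yl is an aromatic group, as naphthalen-1-yl is, but it carries fewer heavy atoms and a single ring, so compound 3 is expected to land between the two measured compounds, with a step of a number 10.9 percentage points lower from compound 2 to compound 3 (beyond the scatter). Compound 3 is therefore estimated at 28% in this assay, within a range from 12% to 45%.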

Compound 3, a percentage reported as inhibition, at one concentration (the size of the read-out at that concentration, not a potency): 18.5%
Compound 3: the middle estimate sits 9.5 percentage points above what was measured; measured number inside the range.
By their numbers in this assay, from the lowest: compounds 1 and 3 (each within the scatter of the next); then compound 2.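

A step of a number 20.4 percentage points lower from compound 2 to compound 3 (beyond the scatter) in this assay shows that an aromatic group on this carbon does not by itself carry the rise seen with naphthalen-1-yl. With a number 0.5 percentage points higher from compound 1 to compound 3 (within the scatter) there is no separation between thiophen-3-yl and bromo at this position, so of the three groups only naphthalen-1-yl stands apart. Nothing in the data gives a reason for the gap between the two aromatic groups.

The compounds shown leave open whether the rise follows the second ring, the heavy-atom count or something particular to naphthalen-1-yl. They also leave open how a phenyl, an amine or a carboxylic acid on this carbon would read, and, as each number comes from a single concentration, they say nothing about potency.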